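A Fluoro Replacement on Two Inactive Caspase-8 Compounds

The source may report more compounds than this note shows. Statements on the series, on what has been measured and on what is new or still open speak of the compounds shown alone.

Compound 1 `COC[C@@H]1CCCN1S(=O)(=O)c1ccc2c(c1)C(=O)C(=O)N2Cc1ccc(O[Si](C)(C)C(C)(C)C)cc1` and compound 2 `COC[C@@H]1CCCN1S(=O)(=O)c1ccc2c(c1)C(=O)C(=O)N2Cc1ccc(OCCOS(=O)(=O)c2ccc(C)cc2)cc1` share one core and differ only in the group carried on the oxygen of the aromatic ring. In an assay on isolated protein for inhibition of Caspase-8 (Homo sapiens) (a higher number here means a weaker inhibitor, a lower number a stronger inhibitor), compound 1 reaches only the limit of > 500000 nM. In this assay compound 2 likewise reaches only the limit of > 500000 nM. Both results sit at the limit of > 500000 nM in this assay, at which 2 of the 2 values shown sit. Compound 3 `COC[C@@H]1CCCN1S(=O)(=O)c1ccc2c(c1)C(=O)C(=O)N2Cc1ccc(OCCF)cc1` is reached from compound 2 by fluoro in place of ((4-methylphenyl)sulfonyl)oxy on a saturated chain carbon, two bonds along the chain from an oxygen on an aromatic ring. For the measured compounds named here, with no measured step to guide it, the expected step of a number no higher from compound 2 to compound 3 (the limit leaves the size open) is none beyond the scatter. Compound 3 is therefore estimated at 500000 nM, within 100000 nM to 2000000 nM, most probably again reported only as a limit.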

Compound 3, half-maximal inhibitory concentration: > 25000 nM
Compound 3: only a limit was reported (the forecaster's own chance of this, stated with the estimate: 80%); the middle value lies beyond the limit too.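

Compound 3 is reported only as a limit, as are compound 1 and compound 2, so neither step to compound 3 can be read. The compounds shown leave open whether fluoro in place of ((4-methylphenyl)sulfonyl)oxy changes inhibition at all.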